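The source may report more compounds than this note shows. Statements on the series, on what has been measured and on what is new or still open speak of the compounds shown alone.

Compound 1 `Cc1cc(-c2nc(C)c([C@H](OC(C)(C)C)C(=O)O)c(-c3ccc4c(c3)CCCO4)c2C)ccc1Cl`: 0.717 h
Compound 2 `Cc1ccc(-c2nc(C)c([C@H](OC(C)(C)C)C(=O)O)c(-c3ccc4c(c3)CCCO4)c2C)cc1C`: 0.567 h

In an ADME assay (liver) for metabolic stability, with Liver microsome (Homo sapiens) as the target, using microsomes (a higher number here means that the compound lasts longer, a lower number that the compound disappears faster), compound 2 gives 0.567 h and sits within the scatter of compound 1, so the two cannot be told apart. Compound 3 `Cc1ccc(-c2nc(C)c([C@H](OC(C)(C)C)C(=O)O)c(-c3ccc4c(c3Cl)NCCO4)c2C)cc1C` keeps the shared core but replaces one large group: a group of 11 heavy atoms (8 carbon, 1 nitrogen, 1 oxygen, 1 chlorine; one six-membered non-aromatic ring with 2 hetero atoms, one six-membered aromatic ring of carbon only) in place of a group of 10 heavy atoms (9 carbon, 1 oxygen; one six-membered non-aromatic ring with 1 hetero atom, one six-membered aromatic ring of carbon only), on an aromatic carbon. The new group is attached at the same place, opposite the ring nitrogen.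

Among the measured compounds shown here, only one measured step is available, a 1.3-fold lower number from compound 1 to compound 2 (0.10 log units; within the scatter). It swaps chloro for methyl elsewhere on the molecule, so it says little about this replacement. For the measured compounds named here, no measured compound carries the entering group, and the data give no direction for the change. No shift beyond the scatter is therefore expected, though the uncertainty is wide. The expected change is a 1.2-fold higher number from compound 2 to compound 3 (0.09 log units; within the scatter). For compound 3, the estimated half-life is 0.7 h, with an expected range of 0.25 h to 2 h.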

Compound 3, half-life: 1.7 h
Beside the measured number, compound 3's estimate is 2.4-fold (0.39 log units) below it; measured number inside the range.
By their numbers in this assay, from the lowest: compounds 2 and 1 (each within the scatter of the next); then compound 3.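

In this assay, among the compounds shown here, replacing the group on the aromatic carbon opposite the ring nitrogen gives a 3.0-fold higher number from compound 2 to compound 3 (0.48 log units; beyond the scatter), the first step in this set that lies beyond the scatter. This position therefore responds to the group placed on it, whereas the chloro-to-methyl swap elsewhere on the molecule gave a 1.3-fold lower number from compound 1 to compound 2 (0.10 log units; within the scatter), which stays within the scatter. No measurement shown here explains why the number rises.

The entering group differs from the one it replaces in more than one way, as it brings both a chlorine and a ring nitrogen carrying a hydrogen-bond donor, so this single step cannot show which of them matters. A group with that ring nitrogen but fluoro in place of the chlorine, or with a methyl on that nitrogen, would be needed to separate these features.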